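This account rests on a few compounds, and the source may have more. Where it says the series, first, only, none or still open, it means among the compounds named here.

Measured so far:
compound 1, `COc1cccnc1-c1cc(Cl)ccc1NS(=O)(=O)c1ccc(C(C)(C)C)cc1`, in a functional assay on isolated protein for antagonist activity at C-C chemokine receptor type 9 (Homo sapiens), read by calcium flux, with a stated time of 10 min (a higher number here means a weaker inhibitor, a lower number a stronger inhibitor), compound 1 gives 958 nM.
compound 2, `CC(C)(C)c1ccc(S(=O)(=O)Nc2ccc(Cl)cc2-c2ncccc2CO)cc1`, in this assay compound 2 gives 89 nM.

Of the two numbers, compound 2 holds the lower one; its nearest neighbour is compound 1, and the step of an 11-fold lower number from compound 1 to compound 2 (1.03 log units; beyond the scatter) sets the two apart beyond the usual scatter. For the measured compounds named here, that single step, hydroxymethyl in place of methoxy on an aromatic carbon, is the only structural comparison the measured pair offers.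

Compound 3, `CC(C)(C)c1ccc(S(=O)(=O)Nc2ccc(Cl)cc2-c2ncccc2CN)cc1`, differs from compound 2 by amino in place of hydroxy on a saturated chain carbon bound to an aromatic carbon. Going by the values given here, no measured step bears on this change: the one step recorded concerns a different exchange, and it gives no guide to swapping hydroxy for amino on the chain carbon. With nothing pointing either way, the expectation is that the step of a 1.3-fold higher number from compound 2 to compound 3 (0.13 log units; within the scatter) stays within the scatter of the method. Compound 3 is therefore estimated to give about 120 nM in this assay, with a range from 30 nM to 450 nM that allows for the unknown weight of this exchange.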

Compound 3, half-maximal inhibitory concentration: 3160 nM
Beside the measured number, compound 3's estimate is 26-fold (1.42 log units) below it; the whole stated range lies below it.
By their numbers in this assay, from the lowest: compound 2; then compound 1; then compound 3.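

The exchange on the saturated chain carbon bound to an aromatic carbon proves far from neutral in this assay, with a 36-fold higher number from compound 2 to compound 3 (1.55 log units; beyond the scatter), even though hydroxy and amino match in heavy-atom count, hydrogen-bond donors and acceptors, and net charge. The earlier pair showed only that the number could fall with a change at this place, whereas a 3.3-fold higher number from compound 1 to compound 3 (0.52 log units; beyond the scatter) shows that aminomethyl in place of methoxy moves it the other way, by a modest step, so that among these three compounds only the hydroxymethyl group of compound 2 gives a lower number than methoxy. No evidence is available to account for the gap between hydroxy and amino on this chain carbon.

As far as these compounds go, it remains open whether the hydroxy group itself is needed or whether other groups on this carbon, such as a methoxymethyl group, a carboxylic acid or a methylamino group, would come close to hydroxymethyl. A longer chain, such as hydroxyethyl, is also untested by these compounds, so they do not show how far the hydroxy group may sit from the aromatic carbon.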